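The source may hold more compounds than are shown below. What is called first, only, known or untested is meant among the compounds shown, and "the series" means these compounds.

In a functional assay on CCRF-CEM cells (Homo sapiens) for antiproliferative activity, read by MTT assay, with a stated time of 3 days (a lower number here means a stronger inhibitor, a higher number a weaker inhibitor), compound 2 `CCCCCc1ccc(C#Cc2cn(C/C=C/CN3C(=O)c4ccccc4C3=O)c(=O)[nH]c2=O)cc1` gives 23000 nM and compound 1 `CCCCCCC#Cc1cn(C/C=C/CN2C(=O)c3ccccc3C2=O)c(=O)[nH]c1=O` gives 28000 nM, so the two stand level within the scatter. Compound 3 `O=C1c2ccccc2C(=O)N1C/C=C/Cn1cc(C#CCCc2ccccc2)c(=O)[nH]c1=O` differs from compound 2 as follows: phenethyl in place of 4-pentylphenyl on a triple-bonded carbon. For the measured compounds named here, the only measured step bearing on this change, a 1.2-fold lower number from compound 1 to compound 2 (0.09 log units; within the scatter), also replaces the group on that carbon and lies within the scatter, so no step beyond the scatter is expected in this assay. The expected step is a 1.0-fold lower number from compound 2 to compound 3 (0.02 log units; within the scatter). Compound 3 is estimated at 22000 nM, with an expected range of 10000 nM to 50000 nM.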

Compound 3, half-maximal inhibitory concentration: 38000 nM
For compound 3 the middle estimate is 1.7-fold (0.24 log units) below the measured one; the range from low to high includes it.
By their numbers in this assay, from the lowest: compounds 2, 1 and 3 (each within the scatter of the next).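

In this assay, phenethyl in place of 4-pentylphenyl on the triple-bonded carbon gives a 1.7-fold higher number from compound 2 to compound 3 (0.22 log units; within the scatter), and phenyl in place of butyl on the saturated chain gives a 1.4-fold higher number from compound 1 to compound 3 (0.13 log units; within the scatter). Hexyl, 4-pentylphenyl and phenethyl therefore stand level at this position, whether the six-membered aromatic ring is absent, sits directly on the triple-bonded carbon or is carried on a saturated chain. No measurement given here bears on a cause for these numbers. As far as these compounds go, all three groups are carbon only, so it remains open whether an amine or a carboxylic acid at the end of the chain would move the number beyond the scatter.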